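A Cyclobutyl Amide in Place of an Azepane Urea

The source may report more compounds than this note shows. Statements on the series, on what has been measured and on what is new or still open speak of the compounds shown alone.

Compound 1 `Cc1ccc(S(=O)(=O)N2CC(c3nc(-c4cccc(Cl)c4)no3)C2)cc1`: in an assay on HEK293 cells for positive allosteric modulation of metabotropic glutamate receptor 5 (Homo sapiens), read by FLIPR (on this read-out higher numbers stand for an effect only at larger amounts of compound and lower numbers for an effect already at smaller amounts), compound 1 reaches only the assay limit of > 10000 nM.
Compound 2 `COC1CCCN(C(=O)N2CC(c3nc(-c4cccc(Cl)c4)no3)C2)C1`: in this assay compound 2 likewise sits at the limit of > 10000 nM.
Compound 3 `O=C(N1CCCCCC1)N1CC(c2nc(-c3cccc(Cl)c3)no2)C1`: in this assay compound 3 gives 47 nM.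

Among the compounds with values here, compound 3 holds the only real number among the three; the other two compounds stop at the limit, as the limit of > 10000 nM in this assay, at which 2 of the 3 values shown sit, states. Within the data shown here, the one measured step that reaches compound 3 is large: an at least 210-fold lower number from compound 2 to compound 3 (2.32 log units; beyond the scatter). Compound 4 `O=C(C1CCC1)N1CC(c2nc(-c3cccc(Cl)c3)no2)C1` differs from compound 3 as follows: cyclobutyl in place of azepan-1-yl on a carbonyl carbon. Among the measured compounds shown here, no measured step covers a change of this kind, since the step from compound 2 to compound 3 exchanges one nitrogen-bound ring for another on the carbonyl carbon, whereas here the nitrogen-bound azepan-1-yl gives way to a carbon-bound cyclobutyl. What the data do show is that the result in this assay depends strongly on which group sits on that carbonyl carbon, and that two of three variants gave no number at all. Compound 4 is therefore expected to lose ground against compound 3, with the step estimated as a 13-fold higher number from compound 3 to compound 4 (1.11 log units; beyond the scatter), though with wide uncertainty. The expected value for compound 4 in this assay is 600 nM, within the range 80 nM to 6000 nM.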

Compound 4, half-maximal effective concentration: > 10000 nM
Compound 4 gave a limit, no number; the forecaster's own chance of this, stated with the estimate: 30%; at least 16-fold (1.22 log units) between middle value and limit.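

In this assay compound 4 stops at > 10000 nM, which is a limit of the assay and not a number. Placing cyclobutyl instead of azepan-1-yl on the carbonyl carbon gives an at least 210-fold higher number from compound 3 to compound 4 (2.32 log units; beyond the scatter), so this change, which removes the nitrogen bound to the carbonyl carbon and shrinks the ring, loses the measurable value of compound 3 just as the change to 3-methoxypiperidin-1-yl in compound 2 did. Azepan-1-yl in compound 3 thus remains the only group shown that yields a number, and every other compound ends at the limit: the limit of > 10000 nM in this assay, at which 3 of the 4 values shown sit.

Compound 2 and compound 4 both end at limits, and the step between them cannot be read. Also open, going by these compounds, is whether the loss in compound 4 goes with the smaller ring, with carbon in place of nitrogen on the carbonyl carbon, or with both, a question that a cycloheptyl group, which keeps a seven-membered ring on carbon, or a pyrrolidin-1-yl group, which keeps the nitrogen with a smaller ring, would separate.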